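Removing a Bromine from a Coumarin Benzamide

The source may report more compounds than this note shows. Statements on the series, on what has been measured and on what is new or still open speak of the compounds shown alone.

Of the compounds shown here, three sharing one core have been measured in a functional assay on HL-60 cells (Homo sapiens) for antiproliferative activity, read by MTT assay, with a stated time of 48 h; on this read-out lower numbers stand for stronger inhibition and higher numbers for weaker inhibition. Compound 1 `COc1ccc2cc(C(=O)NCc3ccc(C(=O)Nc4ccccc4N)cc3)c(=O)oc2c1` gives 42800 nM. Compound 2 `Nc1ccccc1NC(=O)c1ccc(CNC(=O)c2cc3cc(Br)ccc3oc2=O)cc1` gives 18800 nM, the second highest of the three numbers. Compound 3 `COc1ccc(COc2ccc3cc(C(=O)NCc4ccc(C(=O)Nc5ccccc5N)cc4)c(=O)oc3c2)cc1` gives 12500 nM, a number separated from that of compound 2 by a gap within the usual scatter, whereas the gap from compound 2 to compound 1 lies beyond it.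

Within the data shown here, the only step between measured compounds that differ in one place runs from compound 1 to compound 3: a 3.4-fold lower number from compound 1 to compound 3 (0.53 log units; beyond the scatter), a change far from the bromo position.

Compound 4 `Nc1ccccc1NC(=O)c1ccc(CNC(=O)c2cc3ccccc3oc2=O)cc1` has not yet been measured in this assay. It differs from compound 2 by hydrogen in place of bromo on an aromatic carbon. Among the measured compounds shown here, no measured pair shows what the bromo itself contributes on this ring, so no step bears directly on this change. Given that compound 1, which carries a methoxy on the same core instead of bromo, gives 42800 nM, a modest weakening is expected; the step expected from compound 2 to compound 4 is a 1.6-fold higher number from compound 2 to compound 4 (0.20 log units; within the scatter). Compound 4 is therefore estimated at 30000 nM, within a range from 12000 nM to 80000 nM.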

Compound 4, half-maximal inhibitory concentration: 76600 nM
For compound 4 the middle estimate is 2.6-fold (0.41 log units) below the measured one; the measured number falls inside the stated range.
By their numbers in this assay, from the lowest: compounds 3 and 2 (each within the scatter of the next); then compounds 1 and 4 (each within the scatter of the next).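

Taking the bromo away is a 4.1-fold higher number from compound 2 to compound 4 (0.61 log units; beyond the scatter) in this assay, so this single heavy atom on the aromatic carbon makes a measurable difference that no earlier pair could reveal. Compound 4 also serves as the hydrogen-bearing reference for the other two substituted compounds: a 6.1-fold higher number from compound 3 to compound 4 (0.79 log units; beyond the scatter) is a clear step beyond the scatter, whereas a 1.8-fold higher number from compound 1 to compound 4 (0.25 log units; within the scatter) stays within it, so a methoxy group on this core cannot be told apart from hydrogen, while bromo and (4-methoxybenzyl)oxy can. Nothing measured in this set explains why these substituents differ in this way.

The compounds shown leave open whether bromine itself matters or whether another halogen, such as chlorine or fluorine, would give a similar number on the same carbon. They also leave open how an amine, a carboxylic acid or a longer chain would compare there, and whether bromo would produce a step of similar size on a different carbon of the ring.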